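The source may hold more compounds than are shown below. What is called first, only, known or untested is meant among the compounds shown, and "the series" means these compounds.

Series of pyridinyl-thiourea piperidines, measured in an assay on membranes from brain for binding affinity to Lysophosphatidylserine lipase ABHD12 (Mus musculus), read by fluorescence, with a stated time of 20 min; on this read-out higher numbers stand for weaker inhibition and lower numbers for stronger inhibition:
compound 1, `FC(F)(F)Oc1ccccc1Oc1ccnc(N2CCC(NC(=S)Nc3cccnc3)CC2)c1Cl`, 96 nM;
compound 2, `FC(F)(F)Oc1ccc(Oc2ccnc(N3CCC(NC(=S)Nc4cccnc4)CC3)c2Cl)cc1`, 25 nM;
compound 3, `FC(F)(F)c1cnc(N2CCC(NC(=S)Nc3cccnc3)CC2)c(Cl)c1`, 1100 nM.

Compound 3 gives the highest number of the three in this assay; compound 1 sits lower, compound 2 lower still, both beyond the scatter. Among the measured compounds shown here, the only step measured within the set, a 3.8-fold lower number from compound 1 to compound 2 (0.58 log units; beyond the scatter), concerns the placement of the trifluoromethoxy group on the aryl ether and says nothing about the substituent on the core.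

Compound 4, `Cc1cnc(N2CCC(NC(=S)Nc3cccnc3)CC2)c(Cl)c1`, differs from compound 3 by methyl in place of trifluoromethyl on an aromatic carbon. For the measured compounds named here, no measured step bears on this exchange, so the expectation rests on compound 3 alone and is wide. A small step, within or near the scatter, is expected as a 1.8-fold higher number from compound 3 to compound 4 (0.26 log units; within the scatter). Compound 4 is therefore estimated at 2000 nM, in the range 600 nM to 7000 nM.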

Compound 4, half-maximal inhibitory concentration: 3100 nM
Beside the measured number, compound 4's estimate is 1.6-fold (0.19 log units) below it; the range from low to high includes it.
By their numbers in this assay, from the lowest: compound 2; then compound 1; then compound 3; then compound 4.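

The exchange at this position, para to a large group, now has a measured size: a 2.8-fold higher number from compound 3 to compound 4 (0.45 log units; beyond the scatter). Substituents at this place therefore change the read-out, with trifluoromethyl giving the lower number of the two groups compared. No measurement at hand accounts for the difference.

From the compounds shown here alone, whether a nitrile, a methoxy group or an amine at this position would give a lower or higher number than trifluoromethyl stays open. Also open, going by these compounds, is whether the same exchange would give a step of similar size on a core carrying the aryl ether of compound 2.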